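Adding a Methoxy Group on the Thiazole-Side Phenyl Ring

This account rests on a few compounds, and the source may have more. Where it says the series, first, only, none or still open, it means among the compounds named here.

Compound 1 `COc1ccc(-c2nc(SCC(=O)c3sc(-c4ccccc4)nc3C)nc(N)c2C#N)cc1` was tested in an assay on membranes from CHO cells for displacement of a labelled ligand from adenosine receptor A1 (Homo sapiens), read by scintillation counting, with a stated time of 60 min, tested at 1 uM (a higher number here means more inhibition at the concentration tested (going by the name of the read-out), a lower number less inhibition), and gives -4.6%, the lowest of the two numbers recorded so far. Going by the values given here, its closest companion, compound 2 `Cc1nc(-c2ccccc2)sc1C(=O)CSc1nc(N)c(C#N)c(-c2ccccc2)n1`, gives 9.5% in this assay, and the single change between them, hydrogen in place of methoxy on an aromatic carbon, carries a step of a number 14.1 percentage points higher from compound 1 to compound 2 (beyond the scatter).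

Compound 3 `COc1ccc(-c2nc(C)c(C(=O)CSc3nc(N)c(C#N)c(-c4ccc(OC)cc4)n3)s2)cc1` has not yet been measured. It differs from compound 1 by methoxy in place of hydrogen on an aromatic carbon, placed on the other phenyl ring of the shared core. Among the compounds with values here, the one measured step concerns the same group at a different position and in the opposite direction; removing a methoxy there raised the number modestly. Adding one elsewhere offers no direct precedent, so only a small step is expected, if any: compound 3 is estimated to show -7% (range -22% to 8%), a step of a number 2.4 percentage points lower from compound 1 to compound 3 (within the scatter) that is expected to stay near the scatter.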

Compound 3, a percentage reported as inhibition, at one concentration (the size of the read-out at that concentration, not a potency): 9%
Compound 3: middle estimate off by 16 percentage points, on the low side, outside the stated range (above it).
By their numbers in this assay, from the lowest: compound 1; then compounds 3 and 2 (each within the scatter of the next).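

In this assay, changing phenyl to 4-methoxyphenyl on the second phenyl ring gives a number 13.6 percentage points higher from compound 1 to compound 3 (beyond the scatter), so this position accepts a methoxy group and the number rises instead of falling. The step removing the methoxy from the other ring reads a number 14.1 percentage points higher from compound 1 to compound 2 (beyond the scatter), so starting from compound 1, adding a methoxy on one ring and removing one from the other both raise the number, and the same group does not count the same way on the two rings. Nothing measured here explains this difference between the rings.

Going by these compounds, it remains open whether an amine, a carboxylic acid or a longer chain such as ethoxy in the same place would move the number further. On these data alone, it is also open whether the 4-methoxyphenyl change would give a similar step on compound 2, which has no methoxy on its other ring.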